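A few compounds are considered here, and "the series" means these few. Any claim that something is new, unique, unknown or untested is made for them only; others in the source may bear on it.

Compound 1 `Cn1c(-c2ccc(NC(=O)CSc3nc4ccccc4s3)cc2)nc(-c2ccccc2)c1-c1ccccc1` is the starting point of this note. Within the data shown here, in a functional assay on HT-29 cells (Homo sapiens) for cytotoxicity, read by MTT assay, with a stated time of 24 h, tested at 1.6 ug/mL (a lower number here means a weaker effect, a higher number a stronger effect of the compound at the concentration tested), compound 1 gives 15.3%, the lowest of the two numbers so far. Compound 2 `Cn1nnnc1SCC(=O)Nc1ccc(-c2nc(-c3ccccc3)c(-c3ccccc3)n2C)cc1` differs from it only on the sulfur, and in this assay compound 2 gives 49.8%; the step is a number 34.5 percentage points higher from compound 1 to compound 2 (beyond the scatter), a large change for a single swap at that position.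

Compound 3 `CN(C)/C=C/N1CCN(CC(=O)Nc2ccc(-c3nc(-c4ccccc4)c(-c4ccccc4)n3C)cc2)CC1` is not yet measured. Its change from compound 1 is 4-(2-(dimethylamino)ethenyl)piperazin-1-yl in place of (1,3-benzothiazol-2-yl)sulfanyl on a saturated chain carbon bound to a carbonyl carbon. This is a larger rearrangement than the step to compound 2, removing the sulfur together with the aromatic ring system that was bound to it. Among the measured compounds shown here, the one measured step bearing on this part of the molecule, a number 34.5 percentage points higher from compound 1 to compound 2 (beyond the scatter), shows that changing this end of the chain can move the number strongly upward, with no measured step pointing the other way.

Compound 3 is therefore expected to sit above compound 1, with the estimated step of a number 19.7 percentage points higher from compound 1 to compound 3 (beyond the scatter). For the measured compounds named here, compound 3 is estimated at 35% in this assay, within a wide range from 10% to 65%, given that only one step informs the expectation.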

Compound 3, a percentage reported as activity, at one concentration (the size of the read-out at that concentration, not a potency): 8%
For compound 3 the middle estimate is 27 percentage points above the measured one; measured number below the stated range.
By their numbers in this assay, from the lowest: compounds 3 and 1 (each within the scatter of the next); then compound 2.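

In this assay, the rise seen with (1-methyl-1H-tetrazol-5-yl)sulfanyl does not extend to every replacement on this saturated chain carbon bound to a carbonyl carbon: the result is a number 41.8 percentage points lower from compound 2 to compound 3 (beyond the scatter). Set against (1,3-benzothiazol-2-yl)sulfanyl, 4-(2-(dimethylamino)ethenyl)piperazin-1-yl gives a number 7.3 percentage points lower from compound 1 to compound 3 (within the scatter), so a group without sulfur or an aromatic ring reads the same here as the benzothiazole group, and only compound 2 stands apart among the three. No measured evidence bears on the reason for this result.

Compound 3 changes the sulfur and the attached ring together, leaving open which of the two separates it from compound 2. Also open, as far as these compounds go, is how a plain piperazine without the dimethylaminoethenyl part, or a carboxylic acid at this place, would read.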